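A few compounds are considered here, and "the series" means these few. Any claim that something is new, unique, unknown or untested is made for them only; others in the source may bear on it.

Measured in a functional assay on ZR-75-1 cells (Homo sapiens) for cytotoxicity, read by sulforhodamine B assay, with a stated time of 72 h; on this read-out lower numbers stand for an effect already at smaller amounts and higher numbers for an effect only at larger amounts of compound:
- Compound 1 `Cc1cccc(-c2cc3occ(C)c3c(=O)o2)c1`: 6.3 uM
- Compound 2 `COc1cc(OC)cc(-c2cc3occ(C)c3c(=O)o2)c1`: 30.8 uM

Compound 2 has the higher number of the two, so it needs larger amounts to show an effect, and its gap to compound 1 lies beyond the usual scatter. Compound 3 `COc1cc(-c2cc3occ(C)c3c(=O)o2)cc(OC)c1OC` keeps the core of compound 2 and adds one change, methoxy in place of hydrogen on an aromatic carbon, ortho to two methoxy groups and para to a large group. Among the compounds with values here, no measured pair shows this change. In this assay, only a small step towards a lower number is expected, perhaps none beyond the scatter. The estimated 1.5-fold lower number from compound 2 to compound 3 (0.19 log units; within the scatter) reflects this caution. For compound 3, the expected value is 20 uM, with an estimated range of 7 uM to 60 uM.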

Compound 3, concentration for half-maximal effect: 29.1 uM
Compound 3: the middle estimate sits 1.5-fold (0.16 log units) below what was measured; the range from low to high includes it.
By their numbers in this assay, from the lowest: compound 1; then compounds 3 and 2 (each within the scatter of the next).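

Placing methoxy on the aromatic carbon ortho to two methoxy groups and para to a large group gives a 1.1-fold lower number from compound 2 to compound 3 (0.02 log units; within the scatter) in this assay and so adds no measurable difference at this position. Within the data shown here, this is the first single-place step, and it rests on this one pair alone. Nothing available explains this result.

The compounds shown leave open whether an amine or a carboxylic acid at this position would give a step beyond the scatter. They also leave open whether methoxy would behave the same way with other groups around it.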